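The compounds below may be only part of what the source reports. "The series", "measured", "known", "first", "only" and "open" are said of these compounds alone.

Compound 1 `CN(C)C(=O)c1cc2cnc(Nc3ccc(NC(=O)C4(C(=O)Nc5ccccc5)CC4)cc3)nc2n1C1CCCC1` gives 88.8% in a functional assay on A549 cells (Homo sapiens) for inhibition, read by CCK-8 assay, with a stated time of 72 h, tested at 10 uM; on this read-out higher numbers stand for more inhibition of growth at the one concentration tested and lower numbers for less inhibition of growth; this is the lowest of the three numbers shown, yet its gaps to compound 2 `CN(C)C(=O)c1cc2cnc(Nc3ccc(NC(=O)C4(C(=O)Nc5ccc(O)cc5)CC4)cc3)nc2n1C1CCCC1` at 94.4% and to compound 3 `COC(=O)c1cccc(NC(=O)C2(C(=O)Nc3ccc(Nc4ncc5cc(C(=O)N(C)C)n(C6CCCC6)c5n4)cc3)CC2)c1` at 91% both lie within the scatter. Compound 4 `COc1cccc(NC(=O)C2(C(=O)Nc3ccc(Nc4ncc5cc(C(=O)N(C)C)n(C6CCCC6)c5n4)cc3)CC2)c1` differs from compound 1 by methoxy in place of hydrogen on an aromatic carbon. The two measured replacements of a hydrogen on an aromatic carbon bear on this change: a number 5.6 percentage points higher from compound 1 to compound 2 (within the scatter) and a number 2.2 percentage points higher from compound 1 to compound 3 (within the scatter), neither beyond the scatter, and the swap a number 3.4 percentage points lower from compound 2 to compound 3 (within the scatter) is likewise within it. The expected step is therefore a number 1.2 percentage points higher from compound 1 to compound 4 (within the scatter), nothing beyond the scatter. Compound 4 is estimated at 90%, with a range from 82% to 97%.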

Compound 4, percent growth inhibition at one concentration: 96%
Estimate against measurement, compound 4: 6 percentage points below; measured number inside the range.
By their numbers in this assay, from the lowest: compounds 1, 3, 2 and 4 (each within the scatter of the next).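

In this assay, methoxy on an aromatic carbon meta to a large group is a further replacement of hydrogen on this ring that stays inside the scatter: a number 7.2 percentage points higher from compound 1 to compound 4 (within the scatter). The comparisons with the other substituted compounds read the same way, a number 5 percentage points higher from compound 3 to compound 4 (within the scatter) and a number 1.6 percentage points higher from compound 2 to compound 4 (within the scatter), so these steps separate none of the three groups. Nothing available explains this closeness.

As far as these compounds go, whether any group on this ring can move the read-out beyond the scatter remains open. An amine or a carboxylic acid on the same carbon would test this.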